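A few compounds are considered here, and "the series" means these few. Any claim that something is new, unique, unknown or untested is made for them only; others in the source may bear on it.

Measured so far in a physicochemical assay for lipophilicity; a lower number here means a more polar compound, a higher number a more lipophilic compound:
- compound 1 `N#Cc1ccc(Cn2cncc2CN2CCN(c3cccc(Cl)c3)C(=O)C2=O)cc1`: 1.24
- compound 2 `CCCC[C@H]1CN(c2cccc(C)c2C)CC(=O)N1Cc1cncn1Cc1ccc(C#N)cc1`: > 3.5 (a limit of the assay, not a number)
- compound 3 `N#Cc1ccc(Cn2cncc2CN2CCN(c3ccccc3)C(=O)C2)cc1`: 1.32

Only two of these three results are actual numbers. Compound 1 gives 1.24 and compound 3 gives 1.32, so the two stand within the scatter of each other. Compound 2 gives > 3.5, which is a limit. Compound 1 therefore sits close to compound 3 and offers a firm starting point.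

The next compound to be measured is compound 4 `N#Cc1ccc(Cn2cncc2CN2CCN(c3ccccc3)C(=O)C2=O)cc1`. It keeps the core of compound 1 and has hydrogen in place of chloro on an aromatic carbon, meta to a large group, turning 3-chlorophenyl into phenyl (hydrogen in place of chloro on an aromatic carbon). Among the compounds with values here, no measured pair in this small set shows this change on its own, so the expectation rests on the structural change and on compound 1 at 1.24. A moderate step to a lower number in this assay is expected, larger than the scatter, although the uncertainty is considerable. The expected change is a number 0.59 log units lower from compound 1 to compound 4 (beyond the scatter). For compound 4 the estimated value is 0.65, with an expected range from 0.3 to 1.05.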

Compound 4, partition coefficient: 0.46
Compound 4: the middle estimate sits 0.19 log units above what was measured; measured number inside the range.
By their numbers in this assay, from the lowest: compound 4; then compounds 1 and 3 (each within the scatter of the next). At a limit, above all of these: compound 2.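

In this assay, within the data shown here, compounds 1 and 4 form the first pair in the set that differ in one place, and hydrogen in place of chloro gives a number 0.78 log units lower from compound 1 to compound 4 (beyond the scatter), a modest step. The earlier compounds shown here differed in several places at once, so none of them could tie a change in this read-out to one substituent; this pair shows that, with the core of compound 1 kept, the turn from 3-chlorophenyl to phenyl is enough on its own to move the number beyond the scatter. Nothing measured here accounts for the size or direction of this step, so the pair records the change without explaining it.

Going by these compounds, this is a single replacement at a single aromatic carbon, meta to a large group, so it remains open whether the step reflects something particular to chloro or would be seen with other groups there, such as fluoro, methyl or methoxy. On these data alone, it also remains open how an amine or a carboxylic acid on that same carbon would read in this assay, and whether the step would keep its size on a different core.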